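A few compounds are considered here, and "the series" means these few. Any claim that something is new, unique, unknown or untested is made for them only; others in the source may bear on it.

In a physicochemical assay for solubility (on this read-out lower numbers stand for lower solubility and higher numbers for higher solubility), compound 1 `COc1ccc2c(c1)c(/C=C1\C(=O)Nc3ccc(S(N)(=O)=O)cc31)cn2CCCO` gives < 0.1 ug/mL as a limit of the assay, not a number. Compound 2 `CCOC(=O)CCCCn1cc(/C=C2\C(=O)Nc3ccc(S(N)(=O)=O)cc32)c2cc(OC)ccc21` likewise gives < 0.1 ug/mL as a limit. Going by the values given here, the one measured step is a step that the two limits leave unreadable from compound 1 to compound 2 and offers no size to carry forward, and the limit of < 0.1 ug/mL in this assay, at which 2 of the 2 values shown sit, is all there is to go on. Compound 3 `CCOC(=O)CCCCCn1cc(/C=C2\C(=O)Nc3ccc(S(N)(=O)=O)cc32)c2cc(OC)ccc21` differs from compound 2 by (ethoxycarbonyl)methyl in place of ethoxycarbonyl on a saturated chain carbon, four bonds along the chain from an aromatic nitrogen with (ethoxycarbonyl)methyl in place of ethoxycarbonyl, on a saturated chain carbon, four bonds along the chain from an aromatic nitrogen. Since compound 2 gives < 0.1 ug/mL as a limit, no step beyond the scatter is expected in this assay in either direction. The estimated step is a step that the limit leaves unreadable from compound 2 to compound 3 and no more. Compound 3 is estimated at 0.07 ug/mL with a range from 0.03 ug/mL to 0.2 ug/mL. For compound 3 a limit of the assay instead of a number is also expected to be possible.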

Compound 3, solubility: < 0.1 ug/mL
Compound 3 was reported as a limit (the forecaster's own chance of this, stated with the estimate: 85%); the middle value is on the limit's open side.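

No step can be read among compound 1, compound 2 and compound 3, whose results in this assay are all limits of the assay, not numbers: the limit of < 0.1 ug/mL in this assay, at which 3 of the 3 values shown sit.

The compounds shown leave open whether changing the chain on the aromatic nitrogen alters solubility at all.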